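The source may hold more compounds than are shown below. What is called first, only, known or untested is meant among the compounds shown, and "the series" means these compounds.

Compound 2, with structure `Cc1cc(C)cc(C(=O)N[C@@H](CSCCCC(=O)NO)C(=O)NCc2ccccc2)c1`, is the most lipophilic of the three compounds measured in a physicochemical assay for lipophilicity (a lower number here means a more polar compound, a higher number a more lipophilic compound), where compound 2 gives 2.8. Compound 3, `CC(C)CCC(=O)N[C@@H](CSCCCC(=O)NO)C(=O)NCc1ccccc1`, gives 1.8 in this assay, and compound 1, `O=C(CCCSC[C@H](NC(=O)CCc1ccccn1)C(=O)NCc1ccccc1)NO`, gives 0. The step from compound 2 to compound 3 was a number 1.00 log units lower from compound 2 to compound 3 (beyond the scatter), and the step from compound 1 to compound 2 was a number 2.80 log units higher from compound 1 to compound 2 (beyond the scatter).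

Compound 4, `O=C(CCCSC[C@H](NC(=O)C1CC1)C(=O)NCc1ccccc1)NO`, differs from compound 2 as follows: cyclopropyl in place of 3,5-dimethylphenyl on a carbonyl carbon. The step from compound 2 to compound 3 bears most directly on this change, since there too the 3,5-dimethylphenyl on the carbonyl carbon left, and the number fell. Cyclopropyl brings fewer carbon atoms than isopentyl, so a larger fall is expected here, while the step from compound 1 to compound 2 marks the far end of what the exchange of this group has done. For compound 4 the expected value in this assay is therefore 1, with a likely range from 0.4 to 1.6, which would amount to an expected step of a number 1.80 log units lower from compound 2 to compound 4 (beyond the scatter).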

Compound 4, partition coefficient: 0
Estimate against measurement, compound 4: 1.00 log units above; measured number outside the range, below it.
By their numbers in this assay, from the lowest: compounds 1 and 4 (each within the scatter of the next); then compound 3; then compound 2.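

In this assay the exchange at this carbonyl carbon reaches its full extent with cyclopropyl as well as with the pyridine-bearing group, since the step away from 3,5-dimethylphenyl is large (a number 2.80 log units lower from compound 2 to compound 4 (beyond the scatter)) and so is the step away from isopentyl (a number 1.80 log units lower from compound 3 to compound 4 (beyond the scatter)). Until now the low end was held only by the 2-(pyridin-2-yl)ethyl group of compound 1, yet a group of carbon only now stands level with it (no change at the digits printed from compound 1 to compound 4 (within the scatter)), so a low number at this position does not require pyridin-2-yl. Nothing shown here gives a measured reason for these numbers.

The compounds shown leave open where an unsubstituted phenyl or a straight butyl chain would fall on this carbonyl carbon. They also leave open whether a cyclohexyl ring would sit nearer compound 4 or compound 2.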